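Methyl on the Amide Nitrogen: A Second Test

A few compounds are considered here, and "the series" means these few. Any claim that something is new, unique, unknown or untested is made for them only; others in the source may bear on it.

Measured so far in an assay on cells for inhibition of cytochrome P450 11B2, mitochondrial (Homo sapiens), read by HTRF; a higher number here means a weaker inhibitor, a lower number a stronger inhibitor:
compound 1 `Cc1cc(Cl)ccc1C(=O)N(C)c1cccnc1` gives > 3000 nM
compound 2 `O=C(Nc1cccnc1)c1ccc(Cl)cc1F` gives 297 nM
compound 3 `Cc1cc(Cl)ccc1C(=O)Nc1cccnc1` gives 277 nM

The value for compound 1 is a limit of the assay, not a number. Compound 2 sits at the top of the two numbers shown, though the step of a 1.1-fold lower number from compound 2 to compound 3 (0.03 log units; within the scatter) is within the scatter, so compound 2 and compound 3 are not separated. Compound 4 `CN(C(=O)c1ccc(Cl)cc1F)c1cccnc1` differs from compound 2 in one place: methyl in place of hydrogen on an amide-type nitrogen. The same change, run backwards, is the step of an at least 10-fold lower number from compound 1 to compound 3 (1.03 log units; beyond the scatter), which is large. A large rise in this assay is therefore expected for compound 4, quite possibly reaching a limit, as compound 1 shows (the limit of > 3000 nM in this assay, at which 1 of the 3 values shown sits). The expected step is a 13-fold higher number from compound 2 to compound 4 (1.13 log units; beyond the scatter). Compound 4 is estimated at 4000 nM, with a range from 1500 nM to 15000 nM.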

Compound 4, half-maximal inhibitory concentration: > 3000 nM
Compound 4: no number, only a limit; the forecaster's own chance of this, stated with the estimate: 60%; the middle value lies beyond the limit too.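

In this assay, methyl in place of the amide hydrogen now also weakens inhibition on a second core, with an at least 10-fold higher number from compound 2 to compound 4 (1.00 log units; beyond the scatter). Compound 4 gives only a limit, as does compound 1, so the step between them cannot be read. The change therefore points the same way with either fluoro or methyl on the aromatic carbon: the same change on two cores in this assay, an at least 10-fold lower number (1.03 log units; beyond the scatter) from compound 1 to compound 3 and an at least 10-fold lower number (1.00 log units; beyond the scatter) from compound 4 to compound 2; the limit leaves it open whether they differ

As far as these compounds go, how far compound 1 and compound 4 lie past the limit stays unknown. Also open, from the compounds shown here alone, is how an ethyl group or a longer chain on this nitrogen would compare with methyl.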